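Sulfonamide aryl variation in a two-compound series

A few compounds are considered here, and "the series" means these few. Any claim that something is new, unique, unknown or untested is made for them only; others in the source may bear on it.

- Compound 2 `Cc1ccc(NS(=O)(=O)c2cccc(CCCCCCNC(=O)/C=C/c3cccnc3)c2)cc1`: in an assay on isolated protein for inhibition of Nicotinamide phosphoribosyltransferase (Homo sapiens), read by WST assay, with stated times of 60 min, 5 min and 30 min, in the presence of a further agent that is not named here (on this read-out lower numbers stand for stronger inhibition and higher numbers for weaker inhibition), compound 2 gives 9.78 nM
- Compound 1 `O=C(/C=C/c1cccnc1)NCCCCCc1ccc(S(=O)(=O)Nc2ccccc2)cc1`: in this assay compound 1 gives 28.4 nM

Compound 2 holds the lower of the two numbers; compound 1 sits beyond the scatter above it. Compound 3 `Cc1ccc(C)c(NS(=O)(=O)c2cccc(CCCCCCNC(=O)/C=C/c3cccnc3)c2)c1` differs from compound 2 by 2,5-dimethylphenyl in place of 4-methylphenyl on a sulfonamide nitrogen. Among the measured compounds shown here, no measured pair shows this change, so there is no basis for a large step in either direction; a step within the scatter is expected, the estimate leaning slightly weaker, a 1.5-fold higher number from compound 2 to compound 3 (0.19 log units; within the scatter). Compound 3 is estimated at 15 nM in this assay, within 4 nM to 55 nM.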

Compound 3, half-maximal inhibitory concentration: 11.6 nM
Compound 3: middle estimate off by 1.3-fold (0.11 log units), on the high side; measured number inside the range.
By their numbers in this assay, from the lowest: compounds 2 and 3 (each within the scatter of the next); then compound 1.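

In this assay, 2,5-dimethylphenyl replaces 4-methylphenyl on the sulfonamide nitrogen with a 1.2-fold higher number from compound 2 to compound 3 (0.07 log units; within the scatter), so this position takes the extra methyl carbon without a step beyond the scatter. Among the compounds shown here, this is the first comparison that differs in one place only. Nothing measured here bears on why the two aryl groups read alike.

Still open, as far as these compounds go, is how this position responds to an amine or a carboxylic acid on the aryl ring. Also open, from the compounds shown here alone, is the effect of a longer chain with the sulfonamide aryl group held fixed.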